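The source may report more compounds than this note shows. Statements on the series, on what has been measured and on what is new or still open speak of the compounds shown alone.

- Compound 1 `COC(=O)c1scc(-c2ccc(NC(=O)c3cccc(C(F)(F)F)c3)cc2)c1OC` gives 19300 nM
- Compound 2 `COC(=O)c1scc(-c2ccc(NC(=O)c3ccc(F)c(Cl)n3)cc2)c1OC` gives 16200 nM
- Compound 3 `COC(=O)c1scc(-c2ccc(NC(=O)c3cccc(I)c3)cc2)c1OC` gives 12700 nM

These three values come from a functional assay on HeLa cells (Homo sapiens) for antiproliferative activity, read by MTT assay, with a stated time of 24 h (a higher number here means a weaker inhibitor, a lower number a stronger inhibitor), and the compounds differ only in the group on a carbonyl carbon. Compound 3 reads 12700 nM and cannot be separated from the other two, as a 1.5-fold lower number from compound 1 to compound 3 (0.18 log units; within the scatter) and a 1.3-fold lower number from compound 2 to compound 3 (0.11 log units; within the scatter) both lie within the scatter.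

The next compound changes that same place. Compound 4 `COC(=O)c1scc(-c2ccc(NC(=O)c3ccc(OC)nc3)cc2)c1OC` carries 6-methoxypyridin-3-yl in place of 3-iodophenyl on a carbonyl carbon.

The closest precedents are the two measured swaps between a phenyl group and a pyridinyl group. Both stayed small: a 1.2-fold lower number from compound 1 to compound 2 (0.08 log units; within the scatter) and also a 1.3-fold lower number from compound 2 to compound 3 (0.11 log units; within the scatter) in size. Neither swap is an exact match, however. No measured group at this place holds a methoxy, so the data cannot exclude a larger move, and the range is kept wide.

The step expected in this assay is therefore none beyond the scatter, estimated as a 1.3-fold higher number from compound 3 to compound 4 (0.10 log units; within the scatter) in size. Compound 4 is estimated at 16000 nM as a middle value, with an expected range from 7000 nM to 40000 nM for repeated measurements.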

Compound 4, half-maximal inhibitory concentration: 24400 nM
Beside the measured number, compound 4's estimate is 1.5-fold (0.18 log units) below it, within the range that was stated.
By their numbers in this assay, from the lowest: compounds 3, 2, 1 and 4 (each within the scatter of the next).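

Going by these compounds alone, compound 4 is the first in this set to put a methoxy group at this place, on the carbonyl carbon whose other neighbour is the amide-type nitrogen, yet in this assay all three of its steps lie within the scatter: a 1.9-fold higher number from compound 3 to compound 4 (0.28 log units; within the scatter) and a 1.5-fold higher number from compound 2 to compound 4 (0.18 log units; within the scatter) and also a 1.3-fold higher number from compound 1 to compound 4 (0.10 log units; within the scatter) in size. The change from 3-iodophenyl to 6-methoxypyridin-3-yl takes the group from 0 to 2 hydrogen-bond acceptors and swaps an iodine for a ring nitrogen and an oxygen, and even so the four compounds cannot be told apart in this assay, so this position has not yet shown any measurable preference among these four groups. No separate evidence bears on this result, and the numbers alone offer no explanation for it.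

Going by these compounds, it remains open whether a different kind of group here, such as an amine, a carboxylic acid or a longer alkyl chain, would give a step beyond the scatter. On these data alone, compound 4 also brings its methoxy group and its ring nitrogen in together, so the contribution of each one alone stays unknown.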